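Compound 4 and the piperidin-1-yl swap on the chain

The compounds below may be only part of what the source reports. "The series", "measured", "known", "first", "only" and "open" are said of these compounds alone.

Values from a functional assay on the whole organism with Rattus norvegicus as the target (on this read-out higher numbers stand for an effect only at larger amounts of compound and lower numbers for an effect already at smaller amounts), on the measured compounds:
compound 1 `CN(C)S(=O)(=O)CCn1c(=N)sc2cc(OC(F)(F)F)ccc21` (> 10 mg/kg as a limit, not a number)
compound 2 `N=c1sc2cc(OC(F)(F)F)ccc2n1CC[S+]([O-])c1ccccc1` (4.2 mg/kg)
compound 3 `CS(=O)(=O)CCCn1c(=N)sc2cc(OC(F)(F)F)ccc21` (5 mg/kg)

Going by the values given here, the standing of compound 3 rests on its one step between true numbers, a 1.2-fold higher number from compound 2 to compound 3 (0.08 log units; within the scatter) and no order follows from it. The steps of an at least 2.3-fold lower number from compound 1 to compound 2 (0.37 log units; beyond the scatter) and an at least 2.0-fold lower number from compound 1 to compound 3 (0.30 log units; that floor lies within the scatter) are floors resting on the limit of > 10 mg/kg in this assay, at which 1 of the 3 values shown sits, and give no full size.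

Compound 4 `N=c1sc2cc(OC(F)(F)F)ccc2n1CCN1CCCCC1` carries piperidin-1-yl in place of (methylsulfonyl)methyl on a saturated chain carbon, two bonds along the chain from an aromatic nitrogen. Among the compounds with values here, no measured compound holds piperidin-1-yl, so the measured steps at this place bear on the change only loosely. The expectation rests on a 1.2-fold higher number from compound 2 to compound 3 (0.08 log units; within the scatter) where a large change of group left the number within the scatter, and on the modest floor of an at least 2.3-fold lower number from compound 1 to compound 2 (0.37 log units; beyond the scatter) as a sign that some groups here can do worse. An estimated no change at the digits printed from compound 3 to compound 4 (within the scatter) is expected, with no step beyond the scatter foreseen in either direction. In this assay compound 4 is estimated at 5 mg/kg (expected range 1.5 mg/kg to 15 mg/kg).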

Compound 4, dose for half-maximal effect: 2 mg/kg
For compound 4 the middle estimate is 2.5-fold (0.40 log units) above the measured one; the measured number falls inside the stated range.
By their numbers in this assay, from the lowest: compound 4; then compounds 2 and 3 (each within the scatter of the next). At a limit, above all of these: compound 1.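

At this place, on a saturated chain carbon, two bonds along the chain from an aromatic nitrogen, the earlier true numbers in this assay gave no step beyond the scatter, whereas piperidin-1-yl gives two modest ones: a 2.5-fold lower number from compound 3 to compound 4 (0.40 log units; beyond the scatter) and a 2.1-fold lower number from compound 2 to compound 4 (0.32 log units; beyond the scatter). The position therefore does respond to the group it carries, and the step of an at least 5.0-fold lower number from compound 1 to compound 4 (0.69 log units; beyond the scatter) adds only a floor. Compound 1 stands at a limit, not a number: the limit of > 10 mg/kg in this assay, at which 1 of the 4 values shown sits.

On these data alone, whether the lower number belongs to piperidin-1-yl in particular or to a wider class of groups remains open, since one ring is a single case; morpholin-4-yl, pyrrolidin-1-yl or an open-chain dimethylamino group on the same chain would separate these. What the whole-animal read-out reflects in this series also stays unresolved.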